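The source may hold more compounds than are shown below. What is called first, only, known or untested is meant among the compounds shown, and "the series" means these compounds.

Working notes on the series. Compound 1 `Cc1cc(Nc2cc(-c3ccccc3)[nH]n2)n2nc(SCc3c(Cl)cccc3Cl)nc2n1` and compound 2 `Cc1cc(Nc2cc(-c3ccccc3)[nH]n2)n2nc(SCc3ccc(Br)cc3)nc2n1` share the same core and differ only in the group on the saturated chain carbon bound to a sulfur. In a functional assay on PC-9 cells (Homo sapiens) for inhibition, read by MTT assay, with a stated time of 72 h (on this read-out higher numbers stand for weaker inhibition and lower numbers for stronger inhibition), compound 1 gives 5180 nM and compound 2 gives 4760 nM. Among the compounds with values here, compound 1 holds the higher of the two numbers measured so far, though the gap to compound 2 is a 1.1-fold lower number from compound 1 to compound 2 (0.04 log units; within the scatter) and so tells nothing of order.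

Compound 3 `Cc1cc(Nc2cc(-c3ccccc3)[nH]n2)n2nc(SCc3csc4ccccc34)nc2n1` is the next member, not yet measured. Relative to compound 1 the change is 1-benzothiophen-3-yl in place of 2,6-dichlorophenyl on a saturated chain carbon bound to a sulfur. Within the data shown here, the only step that bears on this position is the one from compound 1 to compound 2, which exchanged one aryl group for another at the same place and gave a 1.1-fold lower number from compound 1 to compound 2 (0.04 log units; within the scatter); no step for a fused bicyclic group at this position has been seen.

On that evidence the exchange is expected to leave the number close to that of compound 1, with a step of a 1.0-fold lower number from compound 1 to compound 3 (0.02 log units; within the scatter) expected, within the scatter. For compound 3 the estimate in this assay is 5000 nM, ranging from 2000 nM to 12500 nM.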

Compound 3, half-maximal inhibitory concentration: 4420 nM
Estimate against measurement, compound 3: 1.1-fold (0.05 log units) above, and the stated range covers the measured number.
By their numbers in this assay, from the lowest: compounds 3, 2 and 1 (each within the scatter of the next).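

In this assay, within the data shown here, the exchange on a saturated chain carbon bound to a sulfur gives a 1.2-fold lower number from compound 1 to compound 3 (0.07 log units; within the scatter) and a 1.1-fold lower number from compound 2 to compound 3 (0.03 log units; within the scatter), so the first fused group at this place, 1-benzothiophen-3-yl, cannot be told apart from either 2,6-dichlorophenyl or 4-bromophenyl on this read-out. Among these compounds, the earlier pair compared only two six-membered aromatic rings of carbon bearing halogen atoms; compounds 1, 2 and 3 now show that adding a five-membered aromatic ring with a sulfur atom and leaving out the halogen atoms also produces no change beyond the scatter. Nothing measured here accounts for this lack of separation.

The compounds shown leave open whether anything at this place can move the number beyond the scatter, since all three groups are aromatic and uncharged. A basic amine such as a piperidine, a carboxylic acid or a longer chain between the sulfur and the ring would test whether the flat result in this assay extends past these three aryl groups.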